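Cytotoxicity notes on the step from compound 2 to compound 4

This account rests on a few compounds, and the source may have more. Where it says the series, first, only, none or still open, it means among the compounds named here.

Measured so far in an ADME assay on Vero cells (Chlorocebus sabaeus) for cytotoxicity; a lower number here means that less compound is tolerated, a higher number that more compound is tolerated:
compound 1 `O=[N+]([O-])c1ccc(-c2nc3cc(Cl)c(Cl)cc3[nH]2)cc1` gives >= 100000 nM
compound 2 `Oc1ccc(-c2nc3cc(C(F)(F)F)ccc3[nH]2)cc1` gives > 100000 nM
compound 3 `O=C(CN1CCN(c2ccccc2)CC1)Nc1ccc(-c2nc3cc(C(F)(F)F)ccc3[nH]2)cc1` gives > 100000 nM

The value of compound 1 in this assay is a limit of the assay and not a number. The value of compound 2 in this assay is likewise a limit. The value of compound 3 in this assay is a limit as well. Compound 2 therefore stands at the limit of > 100000 nM in this assay, at which 2 of the 3 values shown sit, as does compound 3, while compound 1 stands at the limit of >= 100000 nM in this assay, at which 1 of the 3 values shown sits. For the measured compounds named here, nothing in these three values separates one compound from another in this assay, and no step between measured compounds is available.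

Compound 4 `COc1ccc(-c2nc3cc(C(F)(F)F)ccc3[nH]2)cc1` differs from compound 2 by methyl in place of hydrogen on an oxygen on an aromatic ring.

For this assay the step of a number no higher from compound 2 to compound 4 (the limit leaves the size open) is expected to be none beyond the scatter, because compound 2 and compound 3 both rest at the limit of > 100000 nM in this assay, at which 2 of the 3 values shown sit. Compound 4 is expected to give about 100000 nM in this assay, within a range of 30000 nM to 300000 nM. A further limit rather than a number is the most likely outcome for compound 4.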

Compound 4, half-maximal cytotoxic concentration: 15000 nM
Beside the measured number, compound 4's estimate is 6.7-fold (0.82 log units) above it, and the stated range ends above it.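

In this assay, methyl in place of hydrogen on an oxygen on an aromatic ring gives an at least 6.6-fold lower number from compound 2 to compound 4 (0.82 log units; beyond the scatter), the only separation readable among the compounds shown. This position therefore responds to a change as small as hydroxy to methoxy, and compound 4 gives 15000 nM, a measured number rather than a limit. Compound 2 rests at a limit of the assay, so the step has a lower bound and no upper one: the limit of > 100000 nM in this assay, at which 2 of the 4 values shown sit.

Going by these compounds, whether a longer chain such as ethoxy on this oxygen, or an amine in place of the hydroxy, would give a number like that of compound 4 remains open. The compounds shown also leave open whether the same hydroxy to methoxy change would count in the same way on a core carrying other ring substituents.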